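Thiophene-to-pyridine swap in a hydroxyphenyl pyridine series

The source may report more compounds than this note shows. Statements on the series, on what has been measured and on what is new or still open speak of the compounds shown alone.

Compound 1 `Oc1cccc(-c2cc(-c3ccc(Cl)cc3)nc(-c3cccs3)c2)c1`, compound 2 `Oc1cccc(-c2cc(-c3ccc(Cl)cc3)nc(-c3cccnc3)c2)c1` and compound 3 `Oc1ccc(-c2cc(-c3cccc(Cl)c3)nc(-c3cccs3)c2)cc1` have been run in a functional assay on T47D cells (Homo sapiens) for cytotoxicity, read by CCK-8 assay and cell counting, with a stated time of 2 days; a higher number here means a weaker inhibitor, a lower number a stronger inhibitor; compound 4 `Oc1ccc(-c2cc(-c3cccnc3)nc(-c3cccc(Cl)c3)c2)cc1` has not. In this assay compound 1 gives 10500 nM, compound 2 gives 18100 nM and compound 3 gives 5350 nM. The change pyridin-3-yl in place of thiophen-2-yl on an aromatic carbon made a 1.7-fold higher number from compound 1 to compound 2 (0.24 log units; within the scatter). The difference between the core of compound 1 and the core of compound 3 is not broken down here. Compound 4 carries the same kind of change, (pyridin-3-yl in place of thiophen-2-yl on an aromatic carbon), but the place differs: here it is meta to a 3-chlorophenyl group and meta to a 4-hydroxyphenyl group, where before it was meta to a 3-hydroxyphenyl group and meta to a 4-chlorophenyl group. Because the matching change gave a 1.7-fold higher number from compound 1 to compound 2 (0.24 log units; within the scatter), a step of similar size is expected. The step expected is a 1.7-fold higher number from compound 3 to compound 4 (0.23 log units; within the scatter). Compound 4 is thus estimated at 9000 nM, between 4000 nM and 20000 nM.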

Compound 4, half-maximal inhibitory concentration: 25700 nM
Estimate against measurement, compound 4: 2.9-fold (0.46 log units) below, and the stated range ends below it.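

In this assay, pyridin-3-yl in place of thiophen-2-yl gives a 4.8-fold higher number from compound 3 to compound 4 (0.68 log units; beyond the scatter), a step beyond the scatter, whereas the matching step on the core of compound 1 stays within it. The size of the step therefore does not carry over unchanged from one core to the other: the same change on two cores in this assay, a 1.7-fold higher number (0.24 log units; within the scatter) from compound 1 to compound 2 and a 4.8-fold higher number (0.68 log units; beyond the scatter) from compound 3 to compound 4, 2.8-fold (0.45 log units) apart, beyond the scatter of two such steps

These two pairs show that the step depends on the core, but they do not show whether the placement of the hydroxyphenyl group, of the chlorophenyl group, or both together accounts for the gap.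

Going by these compounds, it remains open how a group other than these two rings, such as an amine or a carboxylic acid, would behave at this place on either core.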